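Swapping benzyl for acetyl on an inactive pyridazinone amine

The compounds below may be only part of what the source reports. "The series", "measured", "known", "first", "only" and "open" are said of these compounds alone.

Measured compounds:
compound 1, `O=c1[nH]nc(NCc2ccccc2)cc1-c1ccccc1`, > 10000 nM
compound 2, `O=c1cc(-c2ccccc2)c(NCc2ccccc2)n[nH]1`, > 10000 nM
compound 3, `O=c1[nH]nc(NCc2ccccc2)c2ccccc12`, > 10000 nM

The three measured compounds were tested in an assay for inhibition of casein kinase I isoform alpha (Sus scrofa), read by scintillation counting and 33P incorporation, with a stated time of 30 min, in the presence of a further agent that is not named here; a lower number here means a stronger inhibitor, a higher number a weaker inhibitor. Compound 1 gives only a limit of the assay, > 10000 nM, and not a number. Compound 2 likewise gives only a limit, > 10000 nM. Compound 3 also stops at a limit, > 10000 nM. Among the compounds with values here, because of the limit of > 10000 nM in this assay, at which 3 of the 3 values shown sit, no step between measured compounds can be worked out, and compound 2 stands simply at the limit together with the other two.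

The unmeasured compound 4, `CC(=O)Nc1n[nH]c(=O)cc1-c1ccccc1`, differs from compound 2 in a single place: acetyl in place of benzyl on a nitrogen on an aromatic ring. Since compound 2 shows no measurable inhibition, and neither do its two relatives, there is no measured change in this assay from which to judge the swap; nothing here suggests a gain in potency. Compound 4 is therefore expected to remain weak, with an estimate of 20000 nM, ranging from 5000 nM to 100000 nM. The expected step that the limit leaves unreadable from compound 2 to compound 4 is estimated to be none beyond the scatter, and most likely the assay again reports only a limit.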

Compound 4, half-maximal inhibitory concentration: > 10000 nM
Compound 4: only a limit was reported; the forecaster's own chance of this, stated with the estimate: 80%; the middle value lies beyond the limit too.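

Within the data shown here, compound 2 and compound 4 each stop at a limit rather than a number, so no step between them can be read: the limit of > 10000 nM in this assay, at which 4 of the 4 values shown sit. The compounds shown leave open how acetyl truly compares with benzyl on this nitrogen, and whether any change to the shared core gives measurable inhibition in this assay.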